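Replacing cyclopropylamino with an N-methyl aryl amine

The compounds below may be only part of what the source reports. "The series", "measured", "known", "first", "only" and "open" are said of these compounds alone.

Two compounds in this series carry a measurement. Compound 1 `C=CC(=O)Nc1cc(Nc2ncc(Cl)c(NCc3cccs3)n2)c(OC)cc1N1CCN(C)CC1` gives 270 nM in a functional assay on NCI-H3122 cells (Homo sapiens) for inhibition, read by CellTiter-Glo, with a stated time of 72 h; a lower number here means a stronger inhibitor of growth, a higher number a weaker inhibitor of growth. Going by the values given here, compound 2 `C=CC(=O)Nc1cc(Nc2ncc(Cl)c(NC3CC3)n2)c(OC)cc1N1CCN(C)CC1` gives 3200 nM in this assay, the higher of the two numbers; the one step in the set, a 12-fold higher number from compound 1 to compound 2 (1.07 log units; beyond the scatter), separates compound 2 from compound 1.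

Compound 3 `C=CC(=O)Nc1cc(Nc2ncc(Cl)c(N(C)c3cccc(C(F)(F)F)c3)n2)c(OC)cc1N1CCN(C)CC1` has not yet been measured. It differs from compound 2 in a single place: methyl(3-(trifluoromethyl)phenyl)amino in place of cyclopropylamino on an aromatic carbon. Among the compounds with values here, the only measured step that bears on this change is a 12-fold higher number from compound 1 to compound 2 (1.07 log units; beyond the scatter), a large rise in the number when a substituent carrying an aromatic ring gave way to cyclopropyl at the same nitrogen. Compound 3 brings an aromatic ring back to that nitrogen, although the entering group has no hydrogen-bond donor, which neither measured compound shows, so the step is expected to be smaller than a full return. For compound 3 the step is therefore expected to be a decrease, a 5.3-fold lower number from compound 2 to compound 3 (0.73 log units; beyond the scatter), and the estimated value for compound 3 is 600 nM, within a range of 120 nM to 3000 nM.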

Compound 3, concentration for 50% growth inhibition: 3600 nM
Beside the measured number, compound 3's estimate is 6.0-fold (0.78 log units) below it; measured number above the stated range.
By their numbers in this assay, from the lowest: compound 1; then compounds 2 and 3 (each within the scatter of the next).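

In this assay, replacing cyclopropylamino with methyl(3-(trifluoromethyl)phenyl)amino gives a 1.1-fold higher number from compound 2 to compound 3 (0.05 log units; within the scatter) and so leaves the number within the scatter; an aromatic ring at this position is therefore not enough on its own to reach the level of compound 1. Replacing ((thiophen-2-yl)methyl)amino with the same group gives a 13-fold higher number from compound 1 to compound 3 (1.12 log units; beyond the scatter) and shows that two aromatic substituents at this position can give clearly different numbers, so what compound 1 gains cannot be credited to the presence of an aromatic ring alone. No measurement given here explains this result.

Compound 1 and compound 3 differ at once in the ring, in the link from ring to nitrogen and in the methyl on that nitrogen, so the compounds shown do not tell which of these differences matters. Going by these compounds, a 3-(trifluoromethyl)phenylamino group, which keeps the amine hydrogen, or a benzylamino group, which keeps the carbon link with a six-membered ring, could separate these features, and how either would compare with compound 1 remains open.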